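Fluoro to Chloro on a Phenoxy Group Parked at the Limit

A few compounds are considered here, and "the series" means these few. Any claim that something is new, unique, unknown or untested is made for them only; others in the source may bear on it.

Compound 1 `O=C(O)c1csc([C@H]2CC[C@@H]3[C@@H](COc4ccccc4F)[C@H](O)C[C@@H]3O2)n1` carries a 2-fluorophenyl on an oxygen on a saturated carbon. In an assay on HEK293 cells for agonist activity at prostaglandin E2 receptor EP2 subtype (Homo sapiens), read by a beta-galactosidase reporter and beta-arrestin recruitment, with a stated time of 90 min (on this read-out higher numbers stand for an effect only at larger amounts of compound and lower numbers for an effect already at smaller amounts), compound 1 gives only a limit of the assay, > 10000 nM. Compound 2 `O=C(O)c1csc([C@H]2CC[C@@H]3[C@@H](COc4cccc(F)c4)[C@H](O)C[C@@H]3O2)n1` has 3-fluorophenyl in place of 2-fluorophenyl on that oxygen. In this assay compound 2 also gives only a limit, > 10000 nM. The step that the two limits leave unreadable from compound 1 to compound 2 cannot be read because of the limit of > 10000 nM in this assay, at which 2 of the 2 values shown sit. Compound 3 `O=C(O)c1csc([C@H]2CC[C@@H]3[C@@H](COc4cccc(Cl)c4)[C@H](O)C[C@@H]3O2)n1` is the unmeasured partner of compound 2; the change is chloro in place of fluoro on an aromatic carbon, set meta to a large group. Within the data shown here, no measured step has a readable size, so no direction can be taken from the data; the expectation rests only on both neighbours sitting at the limit (the limit of > 10000 nM in this assay, at which 2 of the 2 values shown sit). The expected step is a step that the limit leaves unreadable from compound 2 to compound 3, that is, a stay at or near the limit. Compound 3 is estimated in this assay at 20000 nM, with a range from 5000 nM to 100000 nM.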

Compound 3, half-maximal effective concentration: > 10000 nM
Compound 3: no number, only a limit (the forecaster's own chance of this, stated with the estimate: 80%); the middle value lies beyond the limit too.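

No step among compound 1, compound 2 and compound 3 can be read in this assay, because each value is only a limit of the assay: the limit of > 10000 nM in this assay, at which 3 of the 3 values shown sit.

On these data alone, whether chloro in place of fluoro, or 3-fluorophenyl in place of 2-fluorophenyl, changes the half-maximal effective concentration at all stays open.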